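Removing the Benzyl Ester from Compound 2

The source may hold more compounds than are shown below. What is called first, only, known or untested is meant among the compounds shown, and "the series" means these compounds.

Of the compounds shown here, two sharing the same core have been tested in a functional assay on the whole organism (Tail, strain ICR) with Mus musculus as the target, in the tail flick test, with a stated time of 90 min, at a dose of 25 umol/kg by the oral route; a lower number here means a weaker effect, a higher number a stronger effect of the compound at the dose given. Compound 1 `O=C(CN(c1nc(Cl)nc2[nH]cnc12)C1CC1)N[C@@H](CO)C(=O)O` carries a free acid, and in this assay compound 1 gives 43.9%. Compound 2 `CSCC[C@H](NC(=O)CN(c1nc(Cl)nc2[nH]cnc12)C1CC1)C(=O)OCc1ccccc1` carries a benzyl ester, and in this assay compound 2 gives 44.6%, the highest of the two numbers, though its nearest neighbour, compound 1, lies only a little lower, within the scatter. Among the compounds with values here, no step between measured compounds differing in a single place is available, so the two values can only be set side by side.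

Compound 3 `CSCC[C@H](NC(=O)CN(c1nc(Cl)nc2[nH]cnc12)C1CC1)C(=O)O` has not yet been measured. It differs from compound 2 by hydrogen in place of benzyl on an oxygen next to a carbonyl group. Within the data shown here, the only guide is that compound 1, which also ends in a free acid, gave 43.9%, a number close to that of compound 2. A small step is therefore expected, a number 4.6 percentage points lower from compound 2 to compound 3 (within the scatter), none beyond the scatter, with at most a slight downward lean. Compound 3 is expected to give 40% in this assay, with a range from 20% to 62%.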

Compound 3, a percentage reported as activity, at one dose (the size of the read-out at that dose, not a potency): 14%
For compound 3 the middle estimate is 26 percentage points above the measured one, outside the stated range (below it).
By their numbers in this assay, from the lowest: compound 3; then compounds 1 and 2 (each within the scatter of the next).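

In this assay, hydrogen in place of benzyl on an oxygen next to a carbonyl group gives a number 30.6 percentage points lower from compound 2 to compound 3 (beyond the scatter), so at this position the benzyl ester and the free acid are far from interchangeable when the (methylsulfanyl)methyl chain is present. The free acid alone does not fix the level of effect: with the acid held constant, (methylsulfanyl)methyl in place of hydroxy on a saturated chain carbon gives a number 29.9 percentage points lower from compound 1 to compound 3 (beyond the scatter), so the outcome of removing the benzyl group may depend on what the chain carries. The data shown give no reason for either drop.

Going by these compounds, it remains open whether a smaller ester such as a methyl or ethyl ester, or a primary amide, would stay close to compound 2 or fall towards compound 3, and so whether the benzyl group itself matters or only the capping of the acid. Also open, on these data alone, is how a benzyl ester would behave on the hydroxy-bearing chain of compound 1, and how these differences would look at other doses.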